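The source may report more compounds than this note shows. Statements on the series, on what has been measured and on what is new or still open speak of the compounds shown alone.

Compound 1, `CC1(C)C(=O)c2ccc(C#Cc3cc(Cl)ccc3OCC(=O)O)cc2S1(=O)=O`, gives 31 nM in an assay on CHO cells for displacement of a labelled ligand from prostaglandin D2 receptor 2 (Homo sapiens), read by scintillation counting; on this read-out higher numbers stand for weaker inhibition and lower numbers for stronger inhibition.
Compound 2, `O=C(O)COc1ccccc1C#Cc1ccccc1Cl`, gives 747 nM in this assay.
Compound 3, `Cc1ccc(S(=O)(=O)N(C)C(C)C)cc1C#Cc1cc(Cl)ccc1OCC(=O)O`, gives 3.8 nM in this assay.

Of the three compounds measured, compound 3 has the lowest number in this assay, and its distance to both compound 1 and compound 2 lies beyond the scatter of the assay, so it counts as the strongest inhibitor of this small set. Compound 2 carries only the shared core with a chlorine and the acid-bearing side chain, and it sits far behind the other two.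

Compound 4, `Cc1ccc(S(=O)(=O)CC(C)C)cc1C#Cc1cc(Cl)ccc1OCC(=O)O`, keeps everything that compound 3 has except one spot on the sulfonyl sulfur: isobutyl in place of isopropyl(methyl)amino on a sulfonyl sulfur. The group that leaves and the group that enters are alike in size and shape and carry no donor or acceptor in either case. For the measured compounds named here, no measured pair shows what such a swap does here, so the expectation rests on that likeness alone. A step from compound 3 to compound 4 of a 1.6-fold higher number from compound 3 to compound 4 (0.20 log units; within the scatter) is expected, which would stay within the scatter or only slightly beyond it. Compound 4 is therefore estimated at 6 nM in this assay, with a likely range from 2 nM to 20 nM.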

Compound 4, inhibition constant: 3 nM
Beside the measured number, compound 4's estimate is 2.0-fold (0.30 log units) above it, and the stated range covers the measured number.
By their numbers in this assay, from the lowest: compounds 4 and 3 (each within the scatter of the next); then compound 1; then compound 2.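

On the sulfonyl sulfur, isobutyl in place of isopropyl(methyl)amino gives a 1.3-fold lower number from compound 3 to compound 4 (0.10 log units; within the scatter) in this assay, so the two compounds cannot be told apart on this read-out. For the compounds shown here, this is the first pair in the set that differs in one place, and it shows that a low number at this position does not depend on the nitrogen of the leaving group, since isobutyl, made of carbon alone, serves equally well. No measurement here bears on why the number holds across this swap.

Going by these compounds, both groups seen on this sulfur are branched and carry no net charge, so what a carboxylic acid, an amine or a longer chain would do there stays open. On these data alone, it is also open whether a much smaller group, such as methyl, would keep the number this low.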